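A few compounds are considered here, and "the series" means these few. Any claim that something is new, unique, unknown or untested is made for them only; others in the source may bear on it.

Compound 1 `O=C1c2sc(C#Cc3ccccc3)nc2CN1C1CC1`: > 10000 nM
Compound 2 `CC1CC(C(=O)N2CCc3nc(C#Cc4ccccc4)sc3C2)C1`: 81 nM

In an assay on HEK293 cells for positive allosteric modulation of metabotropic glutamate receptor 5 (Homo sapiens), read by FLIPR, with a stated time of 1 h (on this read-out lower numbers stand for an effect already at smaller amounts and higher numbers for an effect only at larger amounts of compound), compound 1 gives only > 10000 nM, which is a limit of the assay rather than a number (the limit of > 10000 nM in this assay, at which 1 of the 2 values shown sits). For the measured compounds named here, compound 2 gives 81 nM, the only number measured so far. Compound 3 `O=C(N1CCCC1)N1CCc2nc(C#Cc3ccccc3)sc2C1` differs from compound 2 in one place: pyrrolidin-1-yl in place of 3-methylcyclobutyl on a carbonyl carbon. Going by the values given here, no step between measured compounds shows what this change does, so the expectation rests on compound 2 at 81 nM alone. A modest weakening is expected, a 2.5-fold higher number from compound 2 to compound 3 (0.39 log units; beyond the scatter), close to the usual scatter. Compound 3 is estimated at 200 nM, between 50 nM and 1500 nM.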

Compound 3, half-maximal effective concentration: 9.8 nM
Compound 3: middle estimate off by 20-fold (1.31 log units), on the high side; measured number outside the range, below it.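

Putting pyrrolidin-1-yl in place of 3-methylcyclobutyl on the carbonyl carbon in this assay gives an 8.3-fold lower number from compound 2 to compound 3 (0.92 log units; beyond the scatter). This position therefore responds clearly to the group on the carbonyl, even though both groups count the same number of heavy atoms and differ in that the entering ring holds a nitrogen. Nothing measured here says why the number moves. Still open, as far as these compounds go, is whether a piperidine or an open-chain dimethylamino group on the same carbonyl carbon would keep this gain. A single step also cannot separate the role of the ring nitrogen from that of ring size.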